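The source may hold more compounds than are shown below. What is called first, only, known or untested is meant among the compounds shown, and "the series" means these compounds.

Measured compounds:

Compound 1, `COc1cc(OCc2cccc(COc3ccccc3)c2)c2cc(-c3cn4nc(OC)sc4n3)oc2c1`: 64%
Compound 2, `Cc1nn2cc(-c3cc4ccccc4o3)nc2s1`: 4%

Both compounds were tested in an ADME assay on microsomes from liver (Rattus norvegicus) for metabolic stability, with a stated time of 10 min; on this read-out lower numbers stand for a less stable compound and higher numbers for a more stable compound. Compound 1 has the higher of the two numbers; compound 2, `Cc1nn2cc(-c3cc4ccccc4o3)nc2s1` again for reference, sits well below it, and the gap between them is beyond the usual scatter of this assay. Compound 2 shares the core of compound 1 but carries none of the larger side chains, so the two are not related by a single change and no single step can be read from them.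

Compound 3, `COc1cc(OCc2cccc(OCc3ccccc3)c2)c2cc(-c3cn4nc(OC)sc4n3)oc2c1`, has not been measured. It differs from compound 1 in one place: benzyloxy in place of phenoxymethyl on an aromatic carbon. The two compounds have the same atoms, joined differently.

Among the measured compounds shown here, with no measured step of this kind available, the expectation rests on the closeness of the structures alone, and a step of no more than the usual scatter is expected, in either direction. The expected change is a number 6 percentage points lower from compound 1 to compound 3 (within the scatter). Compound 3 is expected to give 58%, within a range from 35% to 80%.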

Compound 3, percent of the compound remaining: 76%
Beside the measured number, compound 3's estimate is 18 percentage points below it, and the stated range covers the measured number.
By their numbers in this assay, from the lowest: compound 2; then compound 1; then compound 3.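

In this assay, among the compounds shown here, putting benzyloxy in place of phenoxymethyl on an aromatic carbon, meta to a large group, gives a number 12 percentage points higher from compound 1 to compound 3 (beyond the scatter), the only step here that can be read at a single place. The two groups have the same heavy atoms, the same six-membered aromatic ring of carbon only and the same counts of donors and acceptors, so this position responds to how those atoms are joined, not only to which atoms are present, even though the step is modest. No measurement shown accounts for this step, so the reason for it remains unknown.

The compounds shown leave open how this position would respond to a group of a different kind, such as an amine, a carboxylic acid or a longer alkyl chain ending in a phenyl ring, in place of benzyloxy. They also leave open whether the same exchange would give a similar step on another core, and compound 2 cannot help here, as it differs from compound 1 in more than one place.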